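The source may report more compounds than this note shows. Statements on the series, on what has been measured and on what is new or still open speak of the compounds shown alone.

Compound 1 `CN1CCN(c2ccc(Nc3ncc4nc(Nc5ccc(F)cc5)n([C@H]5CCCN(S(=O)(=O)C6CC6)C5)c4n3)cc2)CC1` gives 1320 nM in a functional assay on A549 cells (Homo sapiens) for antiproliferative activity, read by MTT assay, with a stated time of 72 h; on this read-out lower numbers stand for stronger inhibition and higher numbers for weaker inhibition. Compound 2 `CNC(=O)CN1CC[C@H](n2c(Nc3ccc(F)cc3)nc3cnc(Nc4ccc(N5CCN(C)CC5)cc4)nc32)C1` stands without a number: in this assay compound 2 is reported as "not determined" (no result reported), so no result exists for it. Compound 3 `CN1CCN(c2ccc(Nc3ncc4nc(Nc5ccc(F)cc5)n([C@@H]5CCN(S(=O)(=O)C6CC6)C5)c4n3)cc2)CC1` differs from compound 2 in one place (1-(cyclopropylsulfonyl)pyrrolidin-3-yl in place of 1-((methylcarbamoyl)methyl)pyrrolidin-3-yl on an aromatic nitrogen). With no value for compound 2, the step in this assay can be given neither a size nor a direction; what can be said rests on compound 1, which carries the same cyclopropylsulfonyl group and gives 1320 nM. Compound 3 is therefore expected to give about 1200 nM, within a range from 350 nM to 4000 nM.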

Compound 3, half-maximal inhibitory concentration: > 10000 nM
Compound 3: only a limit was reported; the forecaster's own chance of this, stated with the estimate: 5%; at least 8.3-fold (0.92 log units) between middle value and limit.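

In this assay compound 3 gives > 10000 nM, which is a limit and not a number. With the cyclopropylsulfonyl group kept, the size of the ring on this aromatic nitrogen proves to matter: 1-(cyclopropylsulfonyl)pyrrolidin-3-yl in place of 1-(cyclopropylsulfonyl)piperidin-3-yl gives an at least 7.5-fold higher number from compound 1 to compound 3 (0.87 log units; beyond the scatter). Compound 2 has no result, and its step to compound 3 cannot be read, so the sulfonyl and methylcarbamoyl groups on the pyrrolidine remain uncompared. On these data alone, whether a free secondary amine or an acetyl group on the piperidine nitrogen would change the number of compound 1 stays open.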